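This account rests on a few compounds, and the source may have more. Where it says the series, first, only, none or still open, it means among the compounds named here.

Compound 1 `Cc1ccc(Cn2ccnc2/C=N/Nc2nc(NCCN(C)C)c3ccccc3n2)cc1`: 4200 nM
Compound 2 `CN(C)CCNc1nc(N/N=C/c2nccn2Cc2ccc(F)cc2)nc2ccccc12`: 1050 nM

In a functional assay on NCI-H460 cells (Homo sapiens) for cytotoxicity, read by MTT assay, with a stated time of 72 h (on this read-out higher numbers stand for weaker inhibition and lower numbers for stronger inhibition), compound 1 gives the highest of the two numbers; its nearest neighbour is compound 2, with a 4.0-fold lower number from compound 1 to compound 2 (0.60 log units; beyond the scatter). Compound 3 `Cc1ccc(Cn2ccnc2/C=N/Nc2nc(NCCCN(C)C)c3ccccc3n2)cc1` differs from compound 1 by (dimethylamino)methyl in place of dimethylamino on a saturated chain carbon, two bonds along the chain from a nitrogen on an aromatic ring. Among the compounds with values here, the only measured step, the exchange of methyl for fluoro, touches a different part of the shared core and says nothing about lengthening this chain. Within the data shown here, no step in this assay therefore bears on the change, and no step beyond the scatter is expected, no change at the digits printed from compound 1 to compound 3 (within the scatter). Compound 3 is estimated at 4200 nM, within 1400 nM to 12600 nM.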

Compound 3, half-maximal inhibitory concentration: 1690 nM
For compound 3 the middle estimate is 2.5-fold (0.40 log units) above the measured one; low and high end bracket the measured number.
By their numbers in this assay, from the lowest: compounds 2 and 3 (each within the scatter of the next); then compound 1.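

In this assay, within the data shown here, the change from (2-(dimethylamino)ethyl)amino to (3-(dimethylamino)propyl)amino gives a 2.5-fold lower number from compound 1 to compound 3 (0.40 log units; beyond the scatter) and so shows that the number responds to the length of this chain, which the earlier compounds did not vary. The step is modest and rests on this one pair. No measurement shown here explains it. Going by these compounds, it remains open whether a longer chain, such as (4-(dimethylamino)butyl)amino, would lower the number further, and whether the same lengthening holds with the fluoro group of compound 2. A pyrrolidine in place of the dimethylamino group also remains untested among the compounds shown.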